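The source may hold more compounds than are shown below. What is called first, only, known or untested is meant among the compounds shown, and "the series" means these compounds.

Measured compounds:
Compound 1, `O=S(=O)(c1ccc(N2CCCC2)cc1)N1CCCc2ccccc21`; in a physicochemical assay for solubility (on this read-out lower numbers stand for lower solubility and higher numbers for higher solubility), compound 1 gives < 500 nM, a limit of the assay rather than a number.
Compound 2, `O=S(=O)(c1ccc(N2CCC=N2)cc1)N1CCCc2ccccc21`; in this assay compound 2 gives 19000 nM.

Among the compounds with values here, compound 2 carries the only number so far in this assay; the other value shown is a limit, (the limit of < 500 nM in this assay, at which 1 of the 2 values shown sits). Within the data shown here, the step from the first compound to the second, an at least 38-fold higher number from compound 1 to compound 2 (1.57 log units; beyond the scatter), is the one measured change on this core, and it moved from a limit to a number.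

Compound 3, `O=C1CCCN1c1ccc(S(=O)(=O)N2CCCc3ccccc32)cc1`, is not yet measured. Its change from compound 2 is a group of 6 heavy atoms (4 carbon, 1 nitrogen, 1 oxygen; one five-membered non-aromatic ring with 1 hetero atom) in place of a group of 5 heavy atoms (3 carbon, 2 nitrogen; one five-membered non-aromatic ring with 2 hetero atoms), on an aromatic carbon. This alters the same ring that the measured step replaced, so that step bears on it, though its starting point was a limit and its size is known only as a lower bound. For compound 3 a step of a 1.6-fold higher number from compound 2 to compound 3 (0.20 log units; within the scatter) is expected, within the scatter of the measured number. Compound 3 is estimated at 30000 nM, within 8000 nM to 120000 nM.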

Compound 3, solubility: 7800 nM
Beside the measured number, compound 3's estimate is 3.8-fold (0.59 log units) above it, outside the stated range (below it).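

In this assay, this position now offers a comparison between two numbers rather than against a limit, and it shows that the choice between two non-aromatic five-membered rings still matters here: a 2.4-fold lower number from compound 2 to compound 3 (0.39 log units; beyond the scatter). Putting 2-oxopyrrolidin-1-yl in place of pyrrolidin-1-yl gives an at least 15-fold higher number from compound 1 to compound 3 (1.19 log units; beyond the scatter), so two different replacements of pyrrolidin-1-yl on this aromatic carbon each give a large step, while the step between those replacements is modest. Compound 1 remains a limit and not a number, so the large steps from it are known only as lower bounds: the limit of < 500 nM in this assay, at which 1 of the 3 values shown sits.

The compounds shown leave open how an open-chain amide such as acetamido, a morpholine or a carboxylic acid would read at this position. They also leave open how far compound 1 truly lies from compound 2 and compound 3, and how changes elsewhere on the shared core would read.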